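Fluorophenyl isomers on a shared core

A few compounds are considered here, and "the series" means these few. Any claim that something is new, unique, unknown or untested is made for them only; others in the source may bear on it.

The set is followed in a functional assay on HCT-15 cells (Homo sapiens) for inhibition; on this read-out higher numbers stand for weaker inhibition and lower numbers for stronger inhibition. Compound 1 `Oc1cccc(-c2cc(-c3ccc(F)cc3)cc(-c3ccccc3O)n2)c1` carries a 4-fluorophenyl group on the shared core. In this assay compound 1 gives only the limit > 50000 nM, not a number. Compound 2 `Oc1ccc(-c2cc(-c3cccc(F)c3)cc(-c3ccccc3O)n2)cc1` carries a 3-fluorophenyl group instead. In this assay compound 2 likewise gives only the limit > 50000 nM. Going by the values given here, compound 2 thus stands at the limit, and no step between measured compounds can be computed; both values sit at the limit of > 50000 nM in this assay, at which 2 of the 2 values shown sit. Compound 3 `Oc1ccc(-c2cc(-c3ccc(F)cc3)cc(-c3ccccc3O)n2)cc1` differs from compound 2 in one place: 4-fluorophenyl in place of 3-fluorophenyl on an aromatic carbon. Compound 1, which already carries the 4-fluorophenyl group, also reached only its limit. The step from compound 2 to compound 3 is therefore expected to be none beyond the scatter, most probably ending again at a limit, the expected step being a step that the limit leaves unreadable from compound 2 to compound 3. Compound 3 is estimated at 80000 nM, within 20000 nM to 300000 nM.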

Compound 3, half-maximal inhibitory concentration: > 50000 nM
Compound 3: a limit, no number; the forecaster's own chance of this, stated with the estimate: 80%; the middle value does not contradict the limit.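

Compound 3 adds no readable step: its steps from compound 1 and from compound 2 cannot be read, as all three compounds give only a limit: the limit of > 50000 nM in this assay, at which 3 of the 3 values shown sit.

The compounds shown leave open how 3-fluorophenyl compares with 4-fluorophenyl, and 3-hydroxyphenyl with 4-hydroxyphenyl, on the shared core.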